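Lengthening a sulfur-linked chain on a whole-organism rat read-out

The source may report more compounds than this note shows. Statements on the series, on what has been measured and on what is new or still open speak of the compounds shown alone.

Three compounds have been measured in a functional assay on the whole organism for inhibition, with Rattus norvegicus as the target; on this read-out lower numbers stand for an effect already at smaller amounts and higher numbers for an effect only at larger amounts of compound:

Compound 1 `CCCCSc1nsnc1[C@@H]1CN2CCC[C@H]1C2`: 0.018 mg/kg
Compound 2 `CCCSc1nsnc1[C@@H]1CN2CCC[C@H]1C2`: 0.03 mg/kg
Compound 3 `CCCCCSc1nsnc1C1CN2CCC[C@H]1C2`: 0.065 mg/kg

Compound 1 differs from compound 2 by one change, (methyl in place of hydrogen on a saturated chain carbon, three bonds along the chain from a sulfur), and that change made a step of a 1.7-fold lower number from compound 2 to compound 1 (0.22 log units; within the scatter) in this assay. Compound 4 `CCCCCCSc1nsnc1C1CN2CCC[C@H]1C2` is not yet measured; it differs from compound 3 by methyl in place of hydrogen on a saturated chain carbon, five bonds along the chain from a sulfur. This is the same kind of change as from compound 2 to compound 1, but the place is not the same: there the methyl enters three bonds along the chain from a sulfur, here five bonds along. The difference between the cores of compound 2 and compound 3 is not broken down here. Given the small step from compound 2 to compound 1 and the higher number of compound 3, the step from compound 3 to compound 4 is expected to be small, about a 1.1-fold higher number from compound 3 to compound 4 (0.03 log units; within the scatter). Compound 4 is therefore estimated at 0.07 mg/kg in this assay.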

Compound 4, dose for half-maximal effect: 0.1 mg/kg
For compound 4 the middle estimate is 1.4-fold (0.15 log units) below the measured one, within the range that was stated.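

Adding the methyl gives a 1.5-fold higher number from compound 3 to compound 4 (0.19 log units; within the scatter) in this assay, a step that the ordinary spread of repeat measurements could produce by itself. The earlier step on the other core points the opposite way, but the two steps cannot be told apart: the same change on two cores in this assay, a 1.7-fold lower number (0.22 log units; within the scatter) from compound 2 to compound 1 and a 1.5-fold higher number (0.19 log units; within the scatter) from compound 3 to compound 4, 2.6-fold (0.41 log units) apart, within the scatter of two such steps This shows no sign that the change behaves differently on the two cores, but it does not prove that it behaves the same, as each core offers a single pair and the methyl enters at a different place along the chain.

As far as these compounds go, a chain ending in a hydroxyl group or a phenyl ring remains open. So does how the two cores compare when they carry the same chain.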